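The source may hold more compounds than are shown below. What is called first, only, known or untested is meant among the compounds shown, and "the series" means these compounds.

Measured in a functional assay on HCT-116 cells (Homo sapiens) for cytotoxicity, read by MTT assay, with a stated time of 72 h; on this read-out lower numbers stand for stronger inhibition and higher numbers for weaker inhibition:
Compound 1 `Nc1ccc(Nc2c(C(=O)NCc3ccc(F)cc3)nc(Br)c3cccnc23)cc1`: 10000 nM
Compound 2 `C[C@H](Nc1c(C(=O)NCc2ccc(F)cc2)nc(Br)c2cccnc12)c1ccccc1`: > 20000 nM (a limit of the assay)

Compound 2 has only a limit, > 20000 nM, and no number. Compound 3 `NCCNc1c(C(=O)NCc2ccc(F)cc2)nc(Br)c2cccnc12` differs from it by 2-aminoethyl in place of 1-phenylethyl on a nitrogen on an aromatic ring, with 2-aminoethyl in place of 1-phenylethyl on a nitrogen on an aromatic ring. Among the measured compounds shown here, the one measured step at this nitrogen is an at least 2.0-fold higher number from compound 1 to compound 2 (0.30 log units; that floor lies within the scatter), and it bears on the change only loosely. For the measured compounds named here, compound 1 at 10000 nM is therefore the sole numeric guide in this assay, and a modest move to a lower number is expected, estimated as an at least 2.0-fold lower number from compound 2 to compound 3 (0.30 log units; that floor lies within the scatter). Compound 3 is estimated at 10000 nM, with an expected range from 3000 nM to 30000 nM.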

Compound 3, half-maximal inhibitory concentration: > 20000 nM
Compound 3: a limit, no number; the forecaster's own chance of this, stated with the estimate: 35%; middle value at least 2.0-fold (0.30 log units) away from the limit.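

In this assay, compound 3 also ends at a limit of the assay, > 20000 nM, so 2-aminoethyl, which has no ring, gives no number on this nitrogen any more than 1-phenylethyl did. Among the compounds shown here, the step between these two limits cannot be read, and the one readable new step is an at least 2.0-fold higher number from compound 1 to compound 3 (0.30 log units; that floor lies within the scatter), which leaves 4-aminophenyl as the only group here with a measured number. The compounds shown now gather at one point: the limit of > 20000 nM in this assay, at which 2 of the 3 values shown sit.

Where compound 2 and compound 3 truly lie remains open. So does whether a longer chain ending in an amine, or a carboxylic acid, on this nitrogen would give a number.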